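Swapping a benzyl for a phenyl on compound 2

The compounds below may be only part of what the source reports. "The series", "measured", "known", "first", "only" and "open" are said of these compounds alone.

Compound 1 `O=C(CCCC(=O)Nc1ccc(NC(=O)Nc2ccc(Cl)c(C(F)(F)F)c2)cc1)NO`: > 10000 nM
Compound 2 `O=C(Nc1ccc2c(c1)CCCN2Cc1ccc(C(=O)NO)cc1)Nc1ccc(Cl)c(C(F)(F)F)c1`: 3000 nM

Both compounds were tested in a functional assay on A549 cells (Homo sapiens) for inhibition, read by sulforhodamine B assay, with a stated time of 48 h; a higher number here means a weaker inhibitor, a lower number a stronger inhibitor. For compound 1, the entry > 10000 nM is a limit of the assay and not a number. For the measured compounds named here, compound 2, at 3000 nM, therefore supplies the only actual number, and nothing else anchors a comparison.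

Compound 3 `O=C(Nc1ccc2c(c1)CCCN2c1ccc(C(=O)NO)cc1)Nc1ccc(Cl)c(C(F)(F)F)c1` keeps the rest of compound 2 and alters one group: 4-(hydroxycarbamoyl)phenyl in place of 4-(hydroxycarbamoyl)benzyl on a nitrogen on an aromatic ring in a ring. Here 4-(hydroxycarbamoyl)phenyl replaces 4-(hydroxycarbamoyl)benzyl on a nitrogen on an aromatic ring in a ring. Going by the values given here, no measured pair shows what this swap does, so the expectation stays close to compound 2 at 3000 nM, with a small lean towards weaker inhibition in this assay. The expected change is a 1.3-fold higher number from compound 2 to compound 3 (0.12 log units; within the scatter), probably no larger than the usual scatter. The estimate for compound 3 is 4000 nM, with an expected range from 1200 nM to 10000 nM.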

Compound 3, half-maximal inhibitory concentration: 2900 nM
For compound 3 the middle estimate is 1.4-fold (0.14 log units) above the measured one; low and high end bracket the measured number.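

In this assay, putting 4-(hydroxycarbamoyl)phenyl in place of 4-(hydroxycarbamoyl)benzyl on a nitrogen on an aromatic ring in a ring gives a 1.0-fold lower number from compound 2 to compound 3 (0.01 log units; within the scatter). For the compounds shown here, this is the first readable step at this position, and it shows that going from 4-(hydroxycarbamoyl)benzyl to 4-(hydroxycarbamoyl)phenyl leaves the read-out unchanged within the scatter. Compound 1 has only a limit of the assay and not a number, so it offers no step that can be read: the limit of > 10000 nM in this assay, at which 1 of the 3 values shown sits.

The compounds shown leave open whether a longer chain, such as 4-(hydroxycarbamoyl)phenethyl, would also leave the number in place at this nitrogen. They also leave open what a carboxylic acid in place of the hydroxycarbamoyl group would do.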